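Taking the hydroxy group away from compound 2

The compounds below may be only part of what the source reports. "The series", "measured", "known", "first", "only" and "open" are said of these compounds alone.

- Compound 1 `CCCCCC[C@@H](O)C/C=C\CCCCCCCC(=O)N[C@@H](C)c1ccccc1` gives 6.7 ug/mL 
- Compound 2 `CCCCCC[C@@H](O)C/C=C\CCCCCCCC(=O)N1CCOCC1` gives 36 ug/mL 

Both values come from a functional assay on 786-0 cells (Homo sapiens) for antiproliferative activity, read by sulforhodamine B assay, with a stated time of 48 h (on this read-out higher numbers stand for weaker inhibition of growth and lower numbers for stronger inhibition of growth), and compound 2 has the higher number of the pair, so it is the weaker growth inhibitor. Compound 3 `CCCCCCCC/C=C\CCCCCCCC(=O)N1CCOCC1` is not yet measured and differs from compound 2 by one change hydrogen in place of hydroxy on a saturated chain carbon bound to two saturated chain carbons with hydrogen in place of hydroxy on a saturated chain carbon bound to two saturated chain carbons. Going by the values given here, the only measured step is a 5.4-fold higher number from compound 1 to compound 2 (0.73 log units; beyond the scatter) and it involves morpholin-4-yl in place of (1-phenylethyl)amino on a carbonyl carbon. That step shows that one change can move the number clearly, yet it says nothing about the hydroxy group. The direction is therefore uncertain, and only a small rise is expected. The estimated 1.3-fold higher number from compound 2 to compound 3 (0.10 log units; within the scatter) stays modest. Compound 3 is expected at 45 ug/mL (estimated range 15 ug/mL to 120 ug/mL).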

Compound 3, concentration for 50% growth inhibition: 4.5 ug/mL
The estimate for compound 3 lay 10-fold (1.00 log units) above the measured number; the measured number lies below the stated range.
By their numbers in this assay, from the lowest: compounds 3 and 1 (each within the scatter of the next); then compound 2.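

In this assay, putting hydrogen in place of hydroxy on a saturated chain carbon bound to two saturated chain carbons gives an 8.0-fold lower number from compound 2 to compound 3 (0.90 log units; beyond the scatter), so compound 3 is the stronger growth inhibitor of this pair. Going by these compounds alone, this is the first direct view of this position, and it shows that the hydroxy group is not a neutral passenger: with morpholin-4-yl on the carbonyl carbon, removing it clearly strengthens growth inhibition. No available evidence explains this shift.

The compounds shown leave open whether the same change would act in the same direction with (1-phenylethyl)amino on the carbonyl carbon. They also do not show how other groups on this carbon, such as an amine or a methoxy group, would compare with hydrogen and hydroxy.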